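Swapping the amide-side phenyl: hydroxy out, fluorine in

The source may report more compounds than this note shows. Statements on the series, on what has been measured and on what is new or still open speak of the compounds shown alone.

Measured so far:
compound 1, `CN(C)C(=O)c1cc2cnc(Nc3ccc(NC(=O)C4(C(=O)Nc5cccc(O)c5)CC4)cc3)nc2n1C1CCCC1`, -19.8%
compound 2, `CN(C)C(=O)c1cc2cnc(Nc3ccc(NC(=O)C4(C(=O)Nc5cccc(Br)c5)CC4)cc3)nc2n1C1CCCC1`, 13.9%
compound 3, `CN(C)C(=O)c1cc2cnc(Nc3ccc(NC(=O)C4(C(=O)Nc5ccc(O)cc5)CC4)cc3)nc2n1C1CCCC1`, 69.5%

These three compounds share one core and differ only in the phenyl group on the outer amide nitrogen. In a functional assay on SiHa cells (Homo sapiens) for inhibition, read by CCK-8 assay, with a stated time of 72 h, tested at 1 uM (a lower number here means less inhibition of growth, a higher number more inhibition of growth at the concentration tested), compound 3 gives the highest of the three numbers; its nearest neighbour is compound 2 and the furthest is compound 1, both beyond the scatter.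

Compound 4, `CN(C)C(=O)c1cc2cnc(Nc3ccc(NC(=O)C4(C(=O)Nc5cccc(F)c5)CC4)cc3)nc2n1C1CCCC1`, is not yet measured. It differs from compound 3 by 3-fluorophenyl in place of 4-hydroxyphenyl on an amide-type nitrogen.

Within the data shown here, two measured steps bear on this. The step of a number 55.6 percentage points higher from compound 2 to compound 3 (beyond the scatter) shows that going from a 3-substituted phenyl to the 4-hydroxyphenyl raised the number strongly, and a number 89.3 percentage points higher from compound 1 to compound 3 (beyond the scatter) shows the same in a larger form. Compound 4 reverses that direction, returning to a 3-substituted phenyl, so a large fall in this assay is expected, roughly back to the level of compound 2. The step of a number 59.5 percentage points lower from compound 3 to compound 4 (beyond the scatter) is therefore estimated, and compound 4 is expected to give 10%, within -25% to 45%.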

Compound 4, percent growth inhibition at one concentration: 29.7%
For compound 4 the middle estimate is 19.7 percentage points below the measured one; the range from low to high includes it.
By their numbers in this assay, from the lowest: compound 1; then compound 2; then compound 4; then compound 3.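

In this assay, the atom on the 3-substituted phenyl ring matters on its own, since the step to fluoro from bromo is modest (a number 15.8 percentage points higher from compound 2 to compound 4 (beyond the scatter)) and the step to fluoro from hydroxy is large (a number 49.5 percentage points higher from compound 1 to compound 4 (beyond the scatter)). Even so, the 3-fluorophenyl group does not match the 4-hydroxyphenyl group on this amide-type nitrogen (a number 39.8 percentage points lower from compound 3 to compound 4 (beyond the scatter)), and compound 3 remains the highest of the four. Nothing measured here explains why these groups differ.

Going by these compounds, only the hydroxy pair, compound 1 and compound 3, compares the two ring placements of one group, so it is open whether a 4-fluorophenyl or 4-bromophenyl group would also rise above its 3-substituted partner. A 4-aminophenyl group would test whether the high number is special to hydroxy.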